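Swapping Methoxy for Fluoro on Compound 2

A few compounds are considered here, and "the series" means these few. Any claim that something is new, unique, unknown or untested is made for them only; others in the source may bear on it.

Measured so far in a functional assay on isolated protein with Glucose-dependent insulinotropic receptor (Mus musculus) as the target, read by HTRF and cAMP accumulation, with a stated time of 45 min; on this read-out higher numbers stand for larger maximal responses and lower numbers for smaller maximal responses:
compound 1 `C[C@@H]1CN(C(=O)OC(C)(C)C)CCN1c1ncc(OCc2ccc(C#N)cc2)cn1` gives 88%
compound 2 `COc1cnccc1COc1cnc(N2CCN(C(=O)OC(C)(C)C)CC2)nc1` gives 5%

Compound 2 stands lowest of the two numbers; compound 1 lies far higher, a gap beyond the usual scatter. Compound 3 `CC(C)(C)OC(=O)N1CCN(c2ncc(OCc3ccncc3F)cn2)CC1` keeps the core of compound 2 and differs in one place: fluoro in place of methoxy on an aromatic carbon. Among the measured compounds shown here, no measured pair shows this single change on its own, so the data give no direct guide. The step of a number 20 percentage points higher from compound 2 to compound 3 (beyond the scatter) is expected to be modest and upward, though its size remains uncertain. In this assay compound 3 is estimated at 25%, between 3% and 70%.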

Compound 3, intrinsic activity: the largest response reached, in percent of the reference agonist's in the Glucose-dependent insulinotropic receptor assay: 157%
The estimate for compound 3 lay 132 percentage points below the measured number; measured number outside the range, above it.
By their numbers in the Glucose-dependent insulinotropic receptor assay, from the lowest: compound 2; then compound 1; then compound 3.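

In the Glucose-dependent insulinotropic receptor assay, fluoro in place of methoxy on this aromatic carbon, two atoms from the ring nitrogen, gives a number 152 percentage points higher from compound 2 to compound 3 (beyond the scatter), so this single position decides whether the shared core gives almost no maximal response or a very large one. In a physicochemical assay for solubility, in phosphate buffer, at pH 7.4 (a lower number here means a less soluble compound, a higher number a more soluble compound), compound 2 gives 11000 nM and compound 3 gives 5100 nM, so the higher maximal response comes with the lower solubility number.

Going by these compounds, what a chloro, a methyl or an amine on this carbon would give stays open. So does whether the same swap would act alike on the core of compound 1.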